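Ester side-chain variants of the shared core: cytotoxicity notes

A few compounds are considered here, and "the series" means these few. Any claim that something is new, unique, unknown or untested is made for them only; others in the source may bear on it.

Measured so far in a functional assay on SW-620 cells (Homo sapiens) for cytotoxicity, read by MTT assay, with a stated time of 72 h; a lower number here means a stronger inhibitor, a higher number a weaker inhibitor:
compound 1 `C#CCn1cc(C(=O)NCCCOC(=O)CNC(=O)OC(C)(C)C)c(=O)c2cccnc21`: > 10000 nM
compound 2 `C#CCn1cc(C(=O)NCCCOC(=O)[C@H]2OC(C)(C)N(C(=O)OC(C)(C)C)[C@@H]2c2ccccc2)c(=O)c2ccc(Cl)nc21`: > 3960 nM
compound 3 `C#CCn1cc(C(=O)NCCCOC(=O)[C@H]2CCCN2C(=O)OC(C)(C)C)c(=O)c2ccc(Cl)nc21`: > 10000 nM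

Each of these three readings is a limit of the assay, not a number. Compound 3 therefore stands only at a limit; the other two readings are limits too, two of the three sitting at the limit of > 10000 nM in this assay, at which 2 of the 3 values shown sit, and one at the limit of > 3960 nM in this assay, at which 1 of the 3 values shown sits. Within the data shown here, no step between measured compounds can be sized.

Compound 4 `C#CCn1cc(C(=O)NCCCOC(=O)[C@H](C)NC(=O)OC(C)(C)C)c(=O)c2ccc(Cl)nc21` differs from compound 3 by 1-((tert-butoxycarbonyl)amino)ethyl in place of 1-(tert-butoxycarbonyl)pyrrolidin-2-yl on a carbonyl carbon. With every reading so far at a limit, no step beyond the scatter is expected in this assay, in either direction. The step from compound 3 to compound 4 is expected to be a step that the limit leaves unreadable from compound 3 to compound 4. Compound 4 is accordingly expected at 15000 nM, within 5000 nM to 50000 nM, most likely reported again as a limit.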

Compound 4, half-maximal inhibitory concentration: > 10000 nM
Compound 4: only a limit was reported; the forecaster's own chance of this, stated with the estimate: 85%; the middle value lies beyond the limit too.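

In this assay compound 4 gives > 10000 nM, a limit and not a number. Among these compounds, compound 3 also stands only at a limit, and no step from it to compound 4 can be read. The compounds shown leave open whether any ester side chain on the shared core reaches a measurable value in this assay.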